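A few compounds are considered here, and "the series" means these few. Any claim that something is new, unique, unknown or untested is made for them only; others in the source may bear on it.

Compound 3 `CCN1CCN(c2c(S(=O)(=O)c3ccccc3)cnc3ccccc23)CC1` sits lowest of the three compounds measured in an assay on isolated protein for displacement of a labelled ligand from metabotropic glutamate receptor 5 (Homo sapiens), with a stated time of 60 min, tested at 1 uM; on this read-out higher numbers stand for more inhibition at the one concentration tested (going by the name of the read-out) and lower numbers for less inhibition: compound 3 gives 1.7%. Compound 2 `NC(=O)C1CCN(c2c(S(=O)(=O)c3ccccc3)cnc3ccccc23)CC1` gives 24.8%, and compound 1 `O=S(=O)(c1cccc(F)c1)c1cnc2cc(Cl)ccc2c1N1CCC(CO)CC1` gives 71%. Among the compounds with values here, the one single-place step in the set is a number 23.1 percentage points lower from compound 2 to compound 3 (beyond the scatter). Compound 4 `CN1CCN(c2c(S(=O)(=O)c3ccccc3)cnc3ccccc23)CC1` differs from compound 3 by hydrogen in place of methyl on a saturated chain carbon bound to an amine nitrogen in a ring, a far smaller change than any step measured so far. Within the data shown here, no measured pair covers an ethyl-to-methyl exchange, so that step offers no direct guide beyond showing how low compound 3 already lies. The step expected in this assay from compound 3 is a number 2.3 percentage points higher from compound 3 to compound 4 (within the scatter), nothing beyond the scatter. Compound 4 is therefore estimated at 4%, with a range from 0% to 20%.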

Compound 4, a percentage reported as inhibition, at one concentration (the size of the read-out at that concentration, not a potency): 7.7%
Beside the measured number, compound 4's estimate is 3.7 percentage points below it; measured number inside the range.
By their numbers in this assay, from the lowest: compounds 3 and 4 (each within the scatter of the next); then compound 2; then compound 1.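

Ethyl and methyl at this place, on a saturated chain carbon bound to an amine nitrogen in a ring, cannot be told apart in this assay (a number 6 percentage points higher from compound 3 to compound 4 (within the scatter)). The step from 4-carbamoylpiperidin-1-yl to 4-methylpiperazin-1-yl also lies beyond the scatter (a number 17.1 percentage points lower from compound 2 to compound 4 (beyond the scatter)), so the low number seen with 4-ethylpiperazin-1-yl is not confined to ethyl. Nothing available explains either result.

Open, on these data alone, is whether a propyl chain in place of ethyl, or hydrogen in place of the whole alkyl group, would move the number beyond the scatter.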